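The source may hold more compounds than are shown below. What is called first, only, known or untested is meant among the compounds shown, and "the series" means these compounds.

Measured so far in a functional assay on HUVEC cells (Homo sapiens) for inhibition, with stated times of 2 h and 72 h; a higher number here means a weaker inhibitor, a lower number a stronger inhibitor:
- Compound 1 `COc1cc2nccc(Oc3ccc4c(NC(=O)c5cc(Cl)ccn5)nn(C)c4c3)c2cc1OC`: > 1000 nM
- Compound 2 `COc1cccc(Nc2nn(C)c3cc(Oc4ccnc5cc(OC)c(OC)cc45)ccc23)c1`: > 1000 nM
- Compound 3 `COc1cc2nccc(Oc3ccc4c(NC(=O)c5cccc(C)c5)nn(C)c4c3)c2cc1OC`: > 1000 nM

Compound 3 gives > 1000 nM, which is a limit and not a number. In fact, everything measured so far rests on (the limit of > 1000 nM in this assay, at which 3 of the 3 values shown sit).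

Compound 4 `COc1cc2nccc(Oc3ccc4c(Nc5ccccc5)nn(C)c4c3)c2cc1OC` carries phenyl in place of (3-methylphenyl)carbonyl on a nitrogen on an aromatic ring.

The nearest measured change is a step that the two limits leave unreadable from compound 2 to compound 3. The others, a step that the two limits leave unreadable from compound 1 to compound 2 and a step that the two limits leave unreadable from compound 1 to compound 3, tell no more. No measured size can therefore be carried over to the new change, and no direction can be drawn from them in this assay.

Compound 2, which also has an aromatic ring on that nitrogen, gives > 1000 nM, again a limit. On that basis, compound 4 is expected to stay in the same weak region, and quite possibly to be reported only as a limit.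

The expected change is a step that the limit leaves unreadable from compound 3 to compound 4, a rough estimate only.

For compound 4 the estimated value is 1500 nM, with an expected range from 300 nM to 5000 nM.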

Compound 4, half-maximal inhibitory concentration: > 1000 nM
Compound 4: a limit, no number; the forecaster's own chance of this, stated with the estimate: 75%; the middle value lies beyond the limit too.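

Compound 4, like compound 1, compound 2 and compound 3, gives only a limit in this assay, so none of the steps to compound 4 can be read: the limit of > 1000 nM in this assay, at which 4 of the 4 values shown sit.

The compounds shown leave open how far any of these changes on the nitrogen shifts inhibition, and in which direction.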